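Chloro for cyano on the pyridine ring of compound 2

A few compounds are considered here, and "the series" means these few. Any claim that something is new, unique, unknown or untested is made for them only; others in the source may bear on it.

Compound 2 `N#Cc1ccc(COc2cc3n(n2)CCCC3)nc1` carries a cyano group on the six-membered aromatic ring with one nitrogen. Among the measured compounds shown here, in a functional assay on HEK293 cells for negative allosteric modulation of metabotropic glutamate receptor 5 (Rattus norvegicus), read by FLIPR and calcium flux, with a stated time of 170 s (a higher number here means a weaker inhibitor, a lower number a stronger inhibitor), compound 2 gives 316 nM, the lowest of the two numbers measured so far. For the measured compounds named here, the only neighbour is compound 1 `c1ccc(COc2cc3n(n2)CCCC3)nc1`, which in this assay gives 2500 nM; the single measured step, a 7.9-fold lower number from compound 1 to compound 2 (0.90 log units; beyond the scatter), is a cyano in place of hydrogen at the same position.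

Compound 3 `Clc1ccc(COc2cc3n(n2)CCCC3)nc1` is not yet measured. It differs from compound 2 by chloro in place of cyano on an aromatic carbon. Going by the values given here, the step from compound 1 to compound 2 bears directly on this change, since it shows what the cyano group itself contributes at this position; removing it would be expected to move the number back toward compound 1, while the entering chloro has no measured precedent. The expected outcome in this assay is therefore a step of moderate size, toward a higher number, roughly a 2.5-fold higher number from compound 2 to compound 3 (0.40 log units; beyond the scatter), landing between the two known values. For compound 3 the estimate in this assay is 800 nM, with a range from 300 nM to 2200 nM.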

Compound 3, half-maximal inhibitory concentration: 1550 nM
Compound 3: the middle estimate sits 1.9-fold (0.29 log units) below what was measured, and the stated range covers the measured number.
By their numbers in this assay, from the lowest: compound 2; then compounds 3 and 1 (each within the scatter of the next).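

In this assay the exchange gives a 4.9-fold higher number from compound 2 to compound 3 (0.69 log units; beyond the scatter) and so the lower number at this position does not carry over from cyano to chloro. Chloro against hydrogen on the same aromatic carbon gives a 1.6-fold lower number from compound 1 to compound 3 (0.21 log units; within the scatter) and these two groups are therefore not told apart in this assay, which leaves cyano, with a 7.9-fold lower number from compound 1 to compound 2 (0.90 log units; beyond the scatter) as its step from hydrogen, as the only one of the three groups at this position that stands clear of the others. The data give no account of why cyano differs from chloro and hydrogen at this position.

Still open, as far as these compounds go, is how other groups on this aromatic carbon would fall relative to cyano, among them fluoro, methoxy, an amine, a primary amide or a carboxylic acid, and whether any of them would match compound 2 or go lower. Also open, from the compounds shown here alone, is whether the gap between cyano and chloro holds when the shared core or the linker to the six-membered aromatic ring is changed, since all three compounds carry the same core and differ in this one place only.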